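Swapping the aryl group on the ring nitrogen

A few compounds are considered here, and "the series" means these few. Any claim that something is new, unique, unknown or untested is made for them only; others in the source may bear on it.

Three compounds built on a shared core differ only in the aryl group carried on an aromatic nitrogen. Compound 1 `CCc1ccccc1-n1nncc1CN1C(=O)C2(C(C#N)=C(N)Oc3c(N)cc4nc5ccccc5nc4c32)c2ccccc21`, bearing a 2-ethylphenyl, gives 24600 nM in a functional assay on MCF7 cells (Homo sapiens) for antiproliferative activity, read by MTT assay, with a stated time of 48 h; a lower number here means a stronger inhibitor, a higher number a weaker inhibitor. Compound 2 `N#CC1=C(N)Oc2c(N)cc3nc4ccccc4nc3c2C12C(=O)N(Cc1cnnn1-c1ccc(F)cc1)c1ccccc12`, with a 4-fluorophenyl, reaches only a limit of > 50000 nM in this assay. Compound 3 `N#CC1=C(N)Oc2c(N)cc3nc4ccccc4nc3c2C12C(=O)N(Cc1cnnn1-c1cccc(Br)c1)c1ccccc12`, with a 3-bromophenyl, likewise gives only a limit of > 50000 nM. Compound 3 thus stands at the limit of > 50000 nM in this assay, at which 2 of the 3 values shown sit. The step of an at least 2.0-fold higher number from compound 1 to compound 2 (0.30 log units; that floor lies within the scatter) and the step of an at least 2.0-fold higher number from compound 1 to compound 3 (0.30 log units; that floor lies within the scatter) both run upward, while the step that the two limits leave unreadable from compound 2 to compound 3 cannot be read. Compound 4 `CC(=O)Nc1ccc(-n2nncc2CN2C(=O)C3(C(C#N)=C(N)Oc4c(N)cc5nc6ccccc6nc5c43)c3ccccc32)cc1` carries the change (4-acetamidophenyl in place of 3-bromophenyl on an aromatic nitrogen). Within the data shown here, of the measured steps, only those starting from compound 1 bear on an aryl swap at this nitrogen, and both ended at the limit; no measured step involves an acetamidophenyl. The expected step of a number no higher from compound 3 to compound 4 (the limit leaves the size open) is therefore small or none beyond the scatter. Compound 4 is estimated at 50000 nM in this assay, between 20000 nM and 120000 nM.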

Compound 4, half-maximal inhibitory concentration: > 50000 nM
Compound 4 was reported as a limit; the forecaster's own chance of this, stated with the estimate: 60%; the middle value sits exactly at the limit.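

Compound 4 also ends at a limit, not a number, in this assay: the limit of > 50000 nM in this assay, at which 3 of the 4 values shown sit. A 4-acetamidophenyl on this nitrogen, with a hydrogen-bond donor and a hydrogen-bond acceptor that the 3-bromophenyl lacks, therefore still gives no reading under that limit. Replacing the 2-ethylphenyl with the 4-acetamidophenyl gives an at least 2.0-fold higher number from compound 1 to compound 4 (0.30 log units; that floor lies within the scatter); the steps linking compound 4 to compound 2 and compound 3 cannot be read, as both ends of each are limits.

Going by these compounds, how far compound 2, compound 3 and compound 4 truly lie apart stays open, as does whether only the 2-ethylphenyl gives a reading under the limit. Also open, on these data alone, is whether a phenyl carrying an amine, a carboxylic acid or a longer alkyl chain at this position would do so.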